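The source may hold more compounds than are shown below. What is called first, only, known or untested is meant among the compounds shown, and "the series" means these compounds.

Measured compounds:
- Compound 1, `COc1ccccc1COc1ccccc1/C=C/C=C1\SC(=S)NC1=O`: 78.8%
- Compound 2, `O=C1NC(=S)S/C1=C\C=C\c1ccccc1OS(=O)(=O)c1ccccc1`: 64.2%

In an assay on isolated protein for inhibition of protein tyrosine phosphatase type IVA 3 (Homo sapiens), tested at 5 ug/mL (on this read-out higher numbers stand for more inhibition at the one concentration tested (going by the name of the read-out) and lower numbers for less inhibition), compound 1 gives 78.8%, the higher of the two numbers available. Compound 2 gives 64.2% in this assay, and the gap between the two lies beyond the scatter of repeated measurements. Among the measured compounds shown here, no pair of measured compounds differs in a single place, so no measured step is available to guide the next move.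

Compound 3, `Cc1ccccc1COc1ccccc1/C=C/C=C1\SC(=S)NC1=O`, has not yet been measured in this assay. It differs from compound 1 by methyl in place of methoxy on an aromatic carbon. The methoxy group that leaves and the methyl group that enters both sit on the same aromatic carbon, and both are small. On that basis the step of a number 8.8 percentage points lower from compound 1 to compound 3 (within the scatter) is expected to be modest and downward, close to the edge of the scatter rather than far beyond it. Compound 3 is therefore estimated at 70%, with a range from 50% to 85%.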

Compound 3, a percentage reported as inhibition, at one concentration (the size of the read-out at that concentration, not a potency): 52.8%
Estimate against measurement, compound 3: 17.2 percentage points above; measured number inside the range.
By their numbers in this assay, from the lowest: compound 3; then compound 2; then compound 1.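

In this assay, methyl in place of methoxy on the aromatic carbon ortho to a large group gives a number 26 percentage points lower from compound 1 to compound 3 (beyond the scatter). Among the compounds shown here, this is the first single-place comparison among the compounds, and it shows that the read-out is sensitive to this position, even for an exchange between two small groups, with methoxy counting one hydrogen-bond acceptor and methyl none. Nothing available explains the fall in the number.

On these data alone, one step at one position cannot show how far the read-out follows the group on this carbon, and it remains open whether a hydroxyl, an ethoxy or a chlorine there would match compound 1 or fall nearer compound 3. Also open, as far as these compounds go, is whether the same exchange on another aromatic carbon of the core would produce a step of similar size.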